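Fluoro in place of hydrogen: compound 2 to compound 3

The source may report more compounds than this note shows. Statements on the series, on what has been measured and on what is new or still open speak of the compounds shown alone.

Among the measured compounds shown here, compound 2 `O=C(Nc1ccc(Oc2ccnc3[nH]ccc23)cc1)c1cn(-c2ccc(F)c(Cl)c2)c2ccccc2c1=O` gives 1120 nM in a functional assay on HepG2 cells (Homo sapiens) for inhibition, read by MTT assay, with a stated time of 72 h (a lower number here means a stronger inhibitor, a higher number a weaker inhibitor), the highest of the two numbers so far; compound 1 `O=C(Nc1ccc(Oc2ccnc3[nH]ccc23)cc1)c1cn(-c2ccc(Cl)cc2)c2ccccc2c1=O` gives 250 nM, and the only measured step, a 4.5-fold higher number from compound 1 to compound 2 (0.65 log units; beyond the scatter), concerns the group on the aromatic nitrogen. Compound 3 `O=C(Nc1ccc(Oc2ccnc3[nH]ccc23)c(F)c1)c1cn(-c2ccc(F)c(Cl)c2)c2ccccc2c1=O` differs from compound 2 by fluoro in place of hydrogen on an aromatic carbon, on the six-membered aromatic ring of carbon only rather than on the aromatic nitrogen, so that step does not bear directly on it. For the measured compounds named here, no measured step touches this ring. No change beyond the scatter is therefore expected, estimated as a 1.1-fold lower number from compound 2 to compound 3 (0.05 log units; within the scatter). Compound 3 is expected at 1000 nM, within 400 nM to 2800 nM.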

Compound 3, half-maximal inhibitory concentration: 3390 nM
For compound 3 the middle estimate is 3.4-fold (0.53 log units) below the measured one; the measured number lies above the stated range.
By their numbers in this assay, from the lowest: compound 1; then compound 2; then compound 3.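

In this assay, this aromatic carbon, ortho to a large group, is not indifferent to substitution: fluoro in place of hydrogen gives a 3.0-fold higher number from compound 2 to compound 3 (0.48 log units; beyond the scatter). The ring of carbon only therefore also affects the number, and a single fluorine atom is enough to move it beyond the scatter. Nothing measured here accounts for the step.

As far as these compounds go, whether a chloro, a methoxy or an amine on this carbon would move the number as fluoro does remains open. So does whether the fluoro step holds with the 4-chlorophenyl group of compound 1 on the aromatic nitrogen.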